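Allyl thioether to bromophenyl ketone on a shared core

A few compounds are considered here, and "the series" means these few. Any claim that something is new, unique, unknown or untested is made for them only; others in the source may bear on it.

This study follows a small set of compounds that share one core, tested in a functional assay on A549 cells (Homo sapiens) for cytotoxicity, read by MTT assay, with a stated time of 48 h; a lower number here means a stronger inhibitor, a higher number a weaker inhibitor. Compound 1 `C#CCSc1nnc(CCC)n1N1C(=O)c2ccccc2C1=O` opens the set. In this assay compound 1 returns only a limit of the measurement, > 200000 nM, and not a number. Among the compounds with values here, compound 2 `C=CCSc1nnc(-c2cc(OC)c(OC)c(OC)c2)n1N1C(=O)c2ccccc2C1=O` differs from compound 1 in two places at once, so no single step links the two. In this assay compound 2 also returns only a limit, > 200000 nM. Where compound 2 stands is thus known to one side only: it sits at the limit of > 200000 nM in this assay, at which 2 of the 2 values shown sit, and on the numbers shown nothing separates it from compound 1. Compound 3 `COc1cc(-c2nnc(SCC(=O)c3ccc(Br)cc3)n2N2C(=O)c3ccccc3C2=O)cc(OC)c1OC` keeps all of compound 2 apart from one change, ((4-bromophenyl)carbonyl in place of vinyl on a saturated chain carbon bound to a sulfur). Within the data shown here, no measured pair in this set spans a change of this kind, so there is no measured step to lean on. With every value shown sitting at the limit, the expected step in this assay is an at least 1.6-fold lower number from compound 2 to compound 3 (0.22 log units; that floor lies within the scatter), and a limit rather than a number remains quite possible. The estimate for compound 3 is 120000 nM, with a range from 20000 nM to 400000 nM.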

Compound 3, half-maximal inhibitory concentration: 16100 nM
The estimate for compound 3 lay 7.5-fold (0.87 log units) above the measured number, outside the stated range (below it).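

In this assay, putting (4-bromophenyl)carbonyl in place of vinyl on a saturated chain carbon bound to a sulfur gives an at least 12-fold lower number from compound 2 to compound 3 (1.09 log units; beyond the scatter), which shows that the group carried on the sulfur can shift this read-out on the shared core. Going by these compounds, the value of compound 2, > 200000 nM, is a limit and not a number, so this step has only a floor and its full size stays unknown. Compound 3 is thus the only compound shown that gives a number in this assay: the limit of > 200000 nM in this assay, at which 2 of the 3 values shown sit.

The change brings in a six-membered aromatic ring, a carbonyl and a bromine all at once, so the compounds shown cannot tell which of these parts carries the step. A plain phenylcarbonyl group without the bromine, a chloro or methoxy group in place of the bromine, or a chain ending in an amine or a carboxylic acid at the same place would begin to pull these parts apart.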